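The source may report more compounds than this note shows. Statements on the series, on what has been measured and on what is new or still open speak of the compounds shown alone.

Measured compounds in a functional assay on SGC-7901 cells (Homo sapiens) for antiproliferative activity, read by MTT assay, with a stated time of 48 h; a lower number here means a stronger inhibitor, a higher number a weaker inhibitor:
compound 1, `COc1cc(OC)c2c(=O)c(OCCCOc3ccccc3/C=C/C(=O)/C=C/c3ccccn3)c(-c3cc(OC)c(OC)c(OC)c3)oc2c1`, 1080 nM
compound 2, `COc1cc(OC)c2c(=O)c(OCCCOc3ccccc3/C=C/C(=O)/C=C/c3scnc3C)c(-c3cc(OC)c(OC)c(OC)c3)oc2c1`, 4780 nM
compound 3, `COc1cc(OC)c2c(=O)c(OCCCCOc3ccc(/C=C/C(=O)/C=C/c4scnc4C)cc3)c(-c3cc(OC)c(OC)c(OC)c3)oc2c1`, 42000 nM

Compound 1 and compound 2 share one core and differ in one place only: pyridin-2-yl in place of 4-methyl-1,3-thiazol-5-yl on a double-bonded chain carbon bound to a double-bonded chain carbon. That change gave a 4.4-fold lower number from compound 2 to compound 1 (0.65 log units; beyond the scatter). Compound 3 is built on a different core; the difference between the core of compound 2 and the core of compound 3 is not broken down here, and what the two values show is that compound 3 gives the higher number of the pair. Compound 3 gives the highest number of the three measured compounds, and its gaps to compound 2 and to compound 1 both lie beyond the scatter.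

Compound 4, `COc1cc(OC)c2c(=O)c(OCCCCOc3ccc(/C=C/C(=O)/C=C/c4ccccn4)cc3)c(-c3cc(OC)c(OC)c(OC)c3)oc2c1`, is not yet measured in this assay. It arises from compound 3 by pyridin-2-yl in place of 4-methyl-1,3-thiazol-5-yl on a double-bonded chain carbon bound to a double-bonded chain carbon, the same change as from compound 2 to compound 1, now made on the core of compound 3. The place is the same in both pairs; only the core around it differs. Within the data shown here, the step is expected to be a 4.2-fold lower number from compound 3 to compound 4 (0.62 log units; beyond the scatter), resting on the single earlier instance of the change, a 4.4-fold lower number from compound 2 to compound 1 (0.65 log units; beyond the scatter), with wider bounds because the core of compound 3 is not the core of compound 2 and nothing else here tells how the change behaves on that core. Compound 4 is therefore estimated at 10000 nM in this assay, with a range of 3500 nM to 30000 nM.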

Compound 4, half-maximal inhibitory concentration: 2410 nM
Compound 4: middle estimate off by 4.1-fold (0.62 log units), on the high side, and the stated range ends above it.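

In this assay, pyridin-2-yl in place of 4-methyl-1,3-thiazol-5-yl gives a 17-fold lower number from compound 3 to compound 4 (1.24 log units; beyond the scatter), so the direction of the step carries from one core to the other, while its size does not: the same change on two cores in this assay, a 4.4-fold lower number (0.65 log units; beyond the scatter) from compound 2 to compound 1 and a 17-fold lower number (1.24 log units; beyond the scatter) from compound 3 to compound 4, 3.9-fold (0.60 log units) apart, beyond the scatter of two such steps

For this series, a step read on one core is therefore a guide to direction on the other core, and its size cannot simply be transferred. Two pairs do not show which part of the difference in the cores goes with the larger step, nor whether the same direction would hold on a third core, and they show nothing about why the two steps differ.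

The compounds shown leave open how other groups would behave in the same place on a double-bonded chain carbon, for instance a plain phenyl ring or a pyridine ring carrying an amine or a carboxylic acid, and whether the size of their steps would also depend on the core. Also open, as far as these compounds go, is whether a longer chain on either core would change the size of this step, and whether the step would keep its direction on cell lines other than this one.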